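The source may hold more compounds than are shown below. What is called first, only, known or untested is meant among the compounds shown, and "the series" means these compounds.

Compound 1 `CCOC(=O)c1cc(-c2ccc(OC)cc2)c(-c2cc(OC)c(OC)c(OC)c2)s1`: 10200 nM
Compound 2 `CCOC(=O)c1cc(-c2ccc(OC)c([N+](=O)[O-])c2)c(-c2cc(OC)c(OC)c(OC)c2)s1`: 24000 nM

For the measured compounds named here, in a functional assay on KB cells (Homo sapiens) for antiproliferative activity, read by MTT assay, with a stated time of 72 h (on this read-out lower numbers stand for stronger inhibition and higher numbers for weaker inhibition), compound 1 gives 10200 nM, the lower of the two numbers measured so far. Compound 3 (`COc1ccc(-c2cc(C(=O)O)sc2-c2cc(OC)c(OC)c(OC)c2)cc1`) keeps the core of compound 1 and changes in one place: hydrogen in place of ethyl on an oxygen next to a carbonyl group. In words, hydrogen replaces ethyl on an oxygen next to a carbonyl group, which turns ethoxycarbonyl into carboxy.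

Going by the values given here, only one measured step is available: a 2.4-fold higher number from compound 1 to compound 2 (0.37 log units; beyond the scatter). That step places nitro on an aromatic carbon and leaves the ethoxycarbonyl group untouched. Among the compounds with values here, it therefore gives a rough idea of scale but no direction for this change, and no measured pair tests the change itself. The direction in this assay is a judgement: a moderately higher number, meaning weaker inhibition, is expected, with a wide range that includes no change beyond the scatter. The expected size is a 2.7-fold higher number from compound 1 to compound 3 (0.44 log units; beyond the scatter). For compound 3 the estimated value is 28000 nM, with an estimated range of 9000 nM to 90000 nM.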

Compound 3, half-maximal inhibitory concentration: 8650 nM
The estimate for compound 3 lay 3.2-fold (0.51 log units) above the measured number, outside the stated range (below it).
By their numbers in this assay, from the lowest: compounds 3 and 1 (each within the scatter of the next); then compound 2.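

In this assay the swap of ethoxycarbonyl for carboxy gives a 1.2-fold lower number from compound 1 to compound 3 (0.07 log units; within the scatter) and so leaves no difference that this assay can resolve between the two compounds. For the compounds shown here, this is the first measured change at this position, on an oxygen next to a carbonyl group, and it shows that the ethyl can give way to hydrogen with the number staying within the usual scatter, whereas the earlier step from compound 1 to compound 2 concerned a different place on the molecule. No measurement at hand bears on why the two compounds read alike.

As far as these compounds go, whether this tolerance extends to other groups on that oxygen remains open: a longer chain such as butyl, or a primary amide in place of the carboxy group, could read quite differently from compound 1 and compound 3. Also open, from the compounds shown here alone, is whether the ethyl-to-hydrogen swap would read the same way on the core of compound 2, which carries the nitro group, since a single pair cannot show whether the result holds on other cores.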